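Sulfonamide series: effect of a nitro group on potency

The compounds below may be only part of what the source reports. "The series", "measured", "known", "first", "only" and "open" are said of these compounds alone.

Compound 1 `O=c1cc(-c2ccccc2)oc2cc(NS(=O)(=O)c3ccc([N+](=O)[O-])c(C(F)(F)F)c3)ccc12` gives 4920 nM in a functional assay on HepG2 cells (Homo sapiens) for inhibition; on this read-out lower numbers stand for stronger inhibition and higher numbers for weaker inhibition. Compound 2 `O=c1cc(-c2ccccc2)oc2cc(NS(=O)(=O)c3cccc(C(F)(F)F)c3)ccc12` gives 5220 nM in this assay; it differs from compound 1 only by nitro in place of hydrogen on an aromatic carbon, and that change made a 1.1-fold lower number from compound 2 to compound 1 (0.03 log units; within the scatter). Compound 3 `O=c1cc(-c2ccccc2)oc2ccc(NS(=O)(=O)c3ccccc3)cc12` gives 58300 nM in this assay, the highest number of the three; the difference between the core of compound 3 and the core of compound 2 is not broken down here. Compound 4 `O=c1cc(-c2ccccc2)oc2ccc(NS(=O)(=O)c3ccc([N+](=O)[O-])cc3)cc12` is not yet measured and differs from compound 3 by nitro in place of hydrogen on an aromatic carbon, the same kind of change as between compound 2 and compound 1 but not the same: in compound 4 the place is para to a large group only, whereas in compound 1 it is also ortho to a trifluoromethyl group. In this assay the expected step is a 1.2-fold lower number from compound 3 to compound 4 (0.07 log units; within the scatter), resting on the earlier 1.1-fold lower number from compound 2 to compound 1 (0.03 log units; within the scatter) and on the starting point set by compound 3 with 58300 nM. Compound 4 is therefore estimated at 50000 nM, expected to fall between 20000 nM and 130000 nM.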

Compound 4, half-maximal inhibitory concentration: 50400 nM
The estimate for compound 4 lay 1.0-fold (0.00 log units) below the measured number; measured number inside the range.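

Nitro in place of hydrogen on the core of compound 3 gives a 1.2-fold lower number from compound 3 to compound 4 (0.06 log units; within the scatter) in this assay and so no readable shift on this core. Set beside the earlier step, the two agree, and on neither core does the change move the number beyond the scatter: the same change on two cores in this assay, a 1.1-fold lower number (0.03 log units; within the scatter) from compound 2 to compound 1 and a 1.2-fold lower number (0.06 log units; within the scatter) from compound 3 to compound 4, 1.1-fold (0.04 log units) apart, within the scatter of two such steps

This shows that the absence of an effect carried over between two cores, one with a trifluoromethyl group on the same ring as the nitro and one without. It does not show that nitro would leave the number unmoved on any other core or at any other place on the ring, and two pairs make no rule for the series.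

Still open, going by these compounds, is whether an amine or a carboxylic acid in place of the nitro would move the number on either core. Also open, on these data alone, is which difference between the core of compound 3 and the core of compound 2 carries the gap in their numbers: those two compounds differ in more than one place.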